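Aryloxy variation on the bicyclic amine series

A few compounds are considered here, and "the series" means these few. Any claim that something is new, unique, unknown or untested is made for them only; others in the source may bear on it.

Measured so far:
compound 1 `COc1cncc(C2=CC3CC(C2)CN(C)C3)c1` — 19%
compound 2 `C1=C(c2cncc(Oc3ccccc3)c2)CC2CNCC1C2` — 52%
compound 3 `CC(C)Oc1cncc(C2=CC3CNCC(C2)C3)c1` — 75%

In an in vitro functional assay on SH-EP1 cells for agonist activity at Neuronal acetylcholine receptor; alpha4/beta2 (Homo sapiens), read by FLIPR and calcium flux (on this read-out lower numbers stand for smaller maximal responses and higher numbers for larger maximal responses), compound 3 gives 75%, the highest of the three numbers; compound 2 lies next, compound 1 furthest off. Among the compounds with values here, the only single-point step measured, a number 23 percentage points higher from compound 2 to compound 3 (beyond the scatter), shows the group on the ring oxygen matters. Compound 4 `COc1cncc(C2=CC3CNCC(C2)C3)c1` differs from compound 3 by methyl in place of isopropyl on an oxygen on an aromatic ring. Within the data shown here, no measured step covers methyl against isopropyl on this oxygen; compound 1 carries methoxy but also differs at the ring nitrogen, so its value only shows that a methoxy compound can sit low. A downward step of moderate size is therefore expected, a number 23 percentage points lower from compound 3 to compound 4 (beyond the scatter), with wide uncertainty. Compound 4 is estimated at 52%, range 28% to 78%.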

Compound 4, largest response reached (reported as percent of maximum), in percent of the reference or control that the assay uses: 72%
Compound 4: the middle estimate sits 20 percentage points below what was measured; low and high end bracket the measured number.
By their numbers in this assay, from the lowest: compound 1; then compound 2; then compounds 4 and 3 (each within the scatter of the next).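

In this assay the oxygen on the aromatic ring tolerates the change from isopropoxy to methoxy, with a number 3 percentage points lower from compound 3 to compound 4 (within the scatter) as the step, while a number 20 percentage points higher from compound 2 to compound 4 (beyond the scatter) sets phenyl apart from methyl at this place. With methoxy held constant, a number 53 percentage points higher from compound 1 to compound 4 (beyond the scatter) places the low value of compound 1 with the methyl on the amine nitrogen in a ring, not with the methoxy group. No evidence bearing on the cause of these steps is available.

From the compounds shown here alone, whether an ethyl or longer chain on the amine nitrogen lowers the response as methyl does remains open. So does the effect of an amine or a hydroxyl in place of the alkoxy group on the aromatic ring.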